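A few compounds are considered here, and "the series" means these few. Any claim that something is new, unique, unknown or untested is made for them only; others in the source may bear on it.

Measured compounds in hand:

compound 1 `Cc1cc(NC(=O)Nc2ccccc2OC(F)(F)F)c2ccccc2n1` — > 25000 nM
compound 2 `CSc1ccc(NC(=O)Nc2cc(C)nc3ccccc23)cc1` — 16000 nM
compound 3 `COC(=O)c1cccc(NC(=O)Nc2cc(C)nc3ccccc23)c1` — 23000 nM

All three were tested in an ADME assay on HepG2 cells (Homo sapiens) for cytotoxicity, with a stated time of 72 h; on this read-out lower numbers stand for an effect already at smaller amounts and higher numbers for an effect only at larger amounts of compound. Compound 1 gives only a limit there, > 25000 nM, which is a bound of the assay and not a number. That limit is the limit of > 25000 nM in this assay, at which 1 of the 3 values shown sits. In this assay compound 2 gives 16000 nM, and compound 3 gives 23000 nM; these two numbers lie within the usual scatter of each other, so no order is drawn between them. For the measured compounds named here, none of the three pairs differs in a single place, so no measured step is available, and the three values simply mark the series as weakly cytotoxic on these cells.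

Compound 4 `Cc1cc(NC(=O)Nc2ccccc2F)c2ccccc2n1` has not yet been measured. Against compound 1 the change is fluoro in place of trifluoromethoxy on an aromatic carbon. The reading for compound 1 is a limit because of the limit of > 25000 nM in this assay, at which 1 of the 3 values shown sits, and the two numbered compounds sit close to that limit as well, so the change is expected to move this assay by no step beyond the scatter, with the new reading most likely again at or near the limit. Compound 4 is expected to give about 30000 nM in this assay, with a range from 12000 nM to 60000 nM. The step this estimate implies, a step that the limit leaves unreadable from compound 1 to compound 4, is expected to be none beyond the scatter.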

Compound 4, half-maximal effective concentration: > 25000 nM
Compound 4: a limit, no number; the forecaster's own chance of this, stated with the estimate: 70%; the middle value does not contradict the limit.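

In this assay compound 4 gives > 25000 nM, a limit and not a number. With compound 1 also at a limit, no step can be read for fluoro in place of trifluoromethoxy: the limit of > 25000 nM in this assay, at which 2 of the 4 values shown sit. The compounds shown leave open where compound 1 and compound 4 truly lie, and whether this change moves the read-out at all.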